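The compounds below may be only part of what the source reports. "The series", "measured", "known", "first", "only" and "open" are said of these compounds alone.

Of the compounds shown here, three have been measured in an ADME assay on microsomes from liver (Homo sapiens) for metabolic stability, read by LC-MS, tested at 1 uM; a higher number here means faster removal of the compound, a lower number slower removal. Compound 1 `c1cc([C@H]2CC[C@]3(CC2)OOC2(O3)C3CC4CC(C3)CC2C4)ccc1OCCCNC1CCOCC1` gives 10 mL.min-1.g-1. Compound 2 `NC(=O)C1CCN(Cc2ccc([C@H]3CC[C@]4(CC3)OOC3(O4)C4CC5CC(C4)CC3C5)cc2)CC1` gives 10 mL.min-1.g-1. Compound 3 `c1cc([C@H]2CC[C@]3(CC2)OOC2(O3)C3CC4CC(C3)CC2C4)ccc1OCCC1CCNCC1` gives only a limit of the assay, < 7 mL.min-1.g-1.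

Compound 3 therefore stands at the floor of what this assay reports, as the limit of < 7 mL.min-1.g-1 in this assay, at which 1 of the 3 values shown sits, shows: no number is known for it, only that it is not higher than that limit. Compound 4 `O[C@H]1CC[C@H](NCCCOc2ccc([C@H]3CC[C@]4(CC3)OOC3(O4)C4CC5CC(C4)CC3C5)cc2)CC1` has not yet been measured. It differs from compound 3 in one place: ((4-hydroxycyclohexyl)amino)methyl in place of piperidin-4-yl on a saturated chain carbon, two bonds along the chain from an oxygen on an aromatic ring.

Within the data shown here, two measured steps bear on this change. an at least 1.4-fold lower number from compound 1 to compound 3 (0.15 log units; that floor lies within the scatter) and an at least 1.4-fold lower number from compound 2 to compound 3 (0.15 log units; that floor lies within the scatter) were both small, and their floors lie within the scatter. The move to compound 4 runs the other way from the first of these, with ((4-hydroxycyclohexyl)amino)methyl entering in place of piperidin-4-yl, so the number for compound 4 is expected to sit close to that of compound 1 and to that of compound 3, with no step beyond the scatter in this assay in either direction. Compound 4 is expected at 8 mL.min-1.g-1, between 4 mL.min-1.g-1 and 16 mL.min-1.g-1, which would be an estimated step of an at least 1.1-fold higher number from compound 3 to compound 4 (0.05 log units; that floor lies within the scatter).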

Compound 4, intrinsic clearance in microsomes: < 7 mL.min-1.g-1
Compound 4: a limit, no number; the forecaster's own chance of this, stated with the estimate: 40%; middle value at least 1.1-fold (0.05 log units) from the limit.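

In this assay compound 4 gives only a limit, < 7 mL.min-1.g-1, and it is the second compound here to end there: the limit of < 7 mL.min-1.g-1 in this assay, at which 2 of the 4 values shown sit.

Putting 4-hydroxycyclohexyl in place of oxan-4-yl on the amine nitrogen is the first change at that nitrogen among these compounds, and it gives an at least 1.4-fold lower number from compound 1 to compound 4 (0.15 log units; that floor lies within the scatter), while the exchange of the whole side group gives an at least 1.4-fold lower number from compound 2 to compound 4 (0.15 log units; that floor lies within the scatter). The step between compound 3 and compound 4 cannot be read, since both are limits, but it does show that 3-((4-hydroxycyclohexyl)amino)propoxy and 2-(piperidin-4-yl)ethoxy both reach the limit at this place.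

From the compounds shown here alone, how far the true numbers of compound 3 and compound 4 lie beyond that limit stays open, so these two side groups cannot be put in order. Also open, going by these compounds, is whether a carboxylic acid on the 4-position of the cyclohexyl ring in place of the hydroxyl, or a longer chain between the ring oxygen and the amine, would bring the number back to a readable value.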